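Sulfonyl substituent change in a CHO.K1 antagonist series

The source may report more compounds than this note shows. Statements on the series, on what has been measured and on what is new or still open speak of the compounds shown alone.

Measured compounds:
- compound 1 `Cc1c(Cc2ccc(C(F)(F)F)cc2S(=O)(=O)c2ccccc2)c2c(n1CC(=O)O)CCNC2=O`: 13 nM
- compound 2 `COc1ccc(S(=O)(=O)c2ccccc2)c(Cc2c3c(n(CC(=O)O)c2C)CCNC3=O)c1`: 3.6 nM
- compound 3 `Cc1c(Cc2ccccc2S(=O)(=O)c2ccccc2F)c2c(n1CC(=O)O)CCNC2=O`: 3.6 nM

All three share one core and were run in a functional assay on CHO.K1 cells for antagonist activity at prostaglandin D2 receptor 2 (Homo sapiens), read by GTPgammaS binding, with a stated time of 1 h; a lower number here means a stronger inhibitor, a higher number a weaker inhibitor. Compound 1 gives 13 nM. Compound 2 gives 3.6 nM. Compound 3 gives 3.6 nM, level with compound 2 at the digits shown and within the scatter of it; together these two sit at the lowest numbers of the three, and compound 1 lies beyond the scatter away from compound 3.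

The next compound, compound 4 `Cc1c(Cc2ccccc2S(=O)(=O)N2CCOCC2)c2c(n1CC(=O)O)CCNC2=O`, has not been measured in this assay. It differs from compound 3 in one place:

morpholin-4-yl in place of 2-fluorophenyl on a sulfonyl sulfur

For the measured compounds named here, no pair among the measured compounds carries this same change, so there is no measured step to lean on. Going by the values given here, the three values only show that the sulfonyl carries an aromatic ring in every compound measured so far, and nothing is known about what its removal does in this assay. The step is expected to be a moderate move toward a higher number, and the expected step is a 4.2-fold higher number from compound 3 to compound 4 (0.62 log units; beyond the scatter). Compound 4 is therefore estimated at 15 nM, with a range from 4 nM to 60 nM.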

Compound 4, half-maximal inhibitory concentration: 22 nM
Beside the measured number, compound 4's estimate is 1.5-fold (0.17 log units) below it, within the range that was stated.
By their numbers in this assay, from the lowest: compounds 2 and 3 (each within the scatter of the next); then compounds 1 and 4 (each within the scatter of the next).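

In this assay, for the compounds shown here, putting morpholin-4-yl in place of 2-fluorophenyl on the sulfonyl sulfur gives a 6.1-fold higher number from compound 3 to compound 4 (0.79 log units; beyond the scatter), a modest step that lies beyond the scatter and is the first reading at this position without an aromatic ring on the sulfonyl. The aromatic ring is therefore not essential for activity in this series, since compound 4 still gives 22 nM with a non-aromatic ring carrying two hetero atoms in its place, although that swap does cost some inhibitory strength. No supporting measurement is available to explain the size of this step.

This single swap changes several things at once, so the compounds shown cannot separate the loss of the aromatic ring from the arrival of the ring nitrogen and oxygen or the loss of the fluorine. A piperidin-1-yl group would test the ring oxygen directly, while a dimethylamino group would test whether any ring is needed on the sulfonyl, and an unsubstituted phenyl would give the reading for the fluorine.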